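This account rests on a few compounds, and the source may have more. Where it says the series, first, only, none or still open, it means among the compounds named here.

In an ADME assay on a cell-free system (plasma, Homo sapiens) for protein binding, read by LC-MS, tested at 5 uM (a higher number here means a larger unbound share of the compound, a lower number a smaller unbound share), compound 1 `CS(=O)(=O)NC(=O)/C=C/c1cn(-c2ccc(Cl)cc2)nc1-c1ccncc1` gives 0.00015 and compound 2 `CS(=O)(=O)NC(=O)C1CC1c1cn(-c2ccc(Cl)cc2)nc1-c1ccncc1` gives 0.0001. Compound 3 `CS(=O)(=O)NC(=O)NCc1cn(-c2ccc(Cl)cc2)nc1-c1ccncc1` gives 0.00041, the highest of the three numbers and beyond the scatter from both others. The next compound, compound 4 `CS(=O)(=O)NC(=O)OCc1cn(-c2ccc(Cl)cc2)nc1-c1ccncc1`, is not yet measured. The change is ((methylsulfonyl)carbamoyl)oxy in place of ((methylsulfonyl)carbamoyl)amino on a saturated chain carbon bound to an aromatic carbon. Within the data shown here, only one measured step bears on it, and only indirectly: a 2.7-fold higher number from compound 1 to compound 3 (0.44 log units; beyond the scatter), a modest step that exchanged 2-((methylsulfonyl)carbamoyl)ethenyl for (((methylsulfonyl)carbamoyl)amino)methyl. Among the measured compounds shown here, no measured pair tests the exchange of amino for oxy itself. The expectation in this assay is therefore a small move towards a lower number, with nothing beyond the scatter. The estimated step is a 1.4-fold lower number from compound 3 to compound 4 (0.14 log units; within the scatter). For compound 4 the estimated unbound fraction is 0.0003, with an expected range from 0.00012 to 0.00075.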

Compound 4, unbound fraction: 0.0003
Compound 4: middle estimate and measured number agree at the digits printed; the measured number falls inside the stated range.
By their numbers in this assay, from the lowest: compounds 2, 1, 4 and 3 (each within the scatter of the next, the first and the last beyond it).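

In this assay, ((methylsulfonyl)carbamoyl)oxy in place of ((methylsulfonyl)carbamoyl)amino on a saturated chain carbon bound to an aromatic carbon gives a 1.4-fold lower number from compound 3 to compound 4 (0.14 log units; within the scatter), so this exchange, which goes from 2 hydrogen-bond donors and 3 acceptors to 1 donor and 4 acceptors, cannot be told apart from no change. Against the ethenyl group, the oxy partner gives a 2.0-fold higher number from compound 1 to compound 4 (0.30 log units; within the scatter), while the amino partner gives a 2.7-fold higher number from compound 1 to compound 3 (0.44 log units; beyond the scatter), although the oxy and amino partners themselves remain within the scatter of each other. No measured evidence accounts for either result.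

On these data alone, whether the read-out holds with a carboxylic acid in place of the ((methylsulfonyl)carbamoyl)oxy group remains open. A longer chain at this saturated chain carbon is also untested in the compounds shown.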